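This account rests on a few compounds, and the source may have more. Where it says the series, first, only, none or still open, it means among the compounds named here.

Measured compounds:
Compound 1 `COc1cccc(OCc2cc(C)nc(-c3ccccn3)n2)c1` gives 2000 nM in a functional assay on cells for antagonist activity at Free fatty acid receptor 1 (Homo sapiens), read by TR-FRET and inositol phosphate accumulation, with a stated time of 2 h; on this read-out lower numbers stand for stronger inhibition and higher numbers for weaker inhibition.
Compound 2 `Cc1cc(COc2cccc(S(C)(=O)=O)c2)nc(-c2ccccn2)n1` reaches only the limit > 39800 nM in this assay; this is a limit, not a number.
Compound 3 `CC1(CS(C)(=O)=O)CN(c2cc(COc3ccc(F)c(F)c3F)nc(-c3ccccn3)n2)C1` gives 6310 nM in this assay.

Among the numbers shown, compound 3 gives the highest; the nearest is compound 1, whose number is lower, beyond the scatter. Compound 4 `COC1(COc2cc(COc3ccc(F)c(F)c3F)nc(-c3ccccn3)n2)COC1` differs from compound 3 in one place: (3-methoxyoxetan-3-yl)methoxy in place of 3-methyl-3-((methylsulfonyl)methyl)azetidin-1-yl on an aromatic carbon. Among the compounds with values here, the only measured step that bears on this change is an at least 19-fold higher number from compound 1 to compound 2 (1.29 log units; beyond the scatter), in which a methylsulfonyl enters for a methoxy and the number rises to a limit (the limit of > 39800 nM in this assay, at which 1 of the 3 values shown sits). The change from compound 3 to compound 4 runs the other way: the group that leaves carries a methylsulfonyl, and the group that enters carries a methoxy. Compound 4 is therefore expected to give a lower number than compound 3, by a moderate step of a 3.9-fold lower number from compound 3 to compound 4 (0.60 log units; beyond the scatter). The estimate for compound 4 in this assay is 1600 nM, between 400 nM and 6300 nM.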

Compound 4, half-maximal inhibitory concentration: 501 nM
The estimate for compound 4 lay 3.2-fold (0.50 log units) above the measured number; the range from low to high includes it.
By their numbers in this assay, from the lowest: compound 4; then compound 1; then compound 3. At a limit, above all of these: compound 2.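

With the (2,3,4-trifluorophenoxy)methyl group held fixed, the step of a 13-fold lower number from compound 3 to compound 4 (1.10 log units; beyond the scatter) shows that the group on this aromatic carbon alone can move the number by a large amount, even though both the leaving and the entering group hold one four-membered non-aromatic ring. Loss of a methylsulfonyl-bearing group here goes with a lower number, the same direction as the reverse of an at least 19-fold higher number from compound 1 to compound 2 (1.29 log units; beyond the scatter), although that change lies at a different place in the molecule. Compound 2 gives only a limit, not a number: the limit of > 39800 nM in this assay, at which 1 of the 4 values shown sits.

The compounds shown leave open which part of the exchanged group carries the step: the methylsulfonyl, the ring, the methoxy or the attaching atom. They also leave open how a simple amine or a carboxylic acid on this carbon would read.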